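Removing the drawn configuration from compound 1

The source may report more compounds than this note shows. Statements on the series, on what has been measured and on what is new or still open speak of the compounds shown alone.

Of the compounds shown here, three have been tested in a functional assay on CHO cells for antagonist activity at sphingosine 1-phosphate receptor 2 (Homo sapiens), read by GTPgammaS binding; on this read-out lower numbers stand for stronger inhibition and higher numbers for weaker inhibition. Compound 1 `C[C@@H](C(=O)O)c1nn(Cc2cn3cc(OCC4CC4)c(Cl)cc3n2)c2ccccc2c1=O` gives 253 nM, which places it second highest of the three numbers. Compound 3 `COc1ccc(Cl)cc1NC(=O)Cc1nn(CC(=O)O)c(=O)c2ccccc12` gives 1190 nM, a weaker result beyond the scatter, while compound 2 `C[C@H](C(=O)O)n1nc(Cn2cc3cc(OCC4CC4)c(Cl)cc3n2)c2ccccc2c1=O` gives 15 nM, a stronger result beyond the scatter; compound 2 and compound 3 differ from compound 1 in several places at once, so their numbers are shown without any single change to tie them to.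

Compound 4 `CC(C(=O)O)c1nn(Cc2cn3cc(OCC4CC4)c(Cl)cc3n2)c2ccccc2c1=O` is the one not yet measured. It differs from compound 1 as follows: the two compounds have the same atoms and bonds; at least one stereo element is drawn with a configuration in one of them and without one in the other: 1 of 1 stereo elements differ; a stereocentre at a saturated chain carbon is drawn R in compound 1 and without a configuration in compound 4. Compound 4 is thus the same substance drawn without a fixed configuration at that carbon, which in practice means a mixture of both forms. Among the measured compounds shown here, no measured pair in this set shows the size of such a change. If the form in compound 1 carries most of the activity, the mixture should be somewhat weaker; if not, about the same or stronger. The expected step from compound 1 to compound 4 is a 1.3-fold higher number from compound 1 to compound 4 (0.10 log units; within the scatter), likely within the scatter. Compound 4 is therefore estimated at 320 nM, with a range of 120 nM to 900 nM.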

Compound 4, half-maximal inhibitory concentration: 31 nM
Compound 4: middle estimate off by 10-fold (1.01 log units), on the high side; measured number below the stated range.
By their numbers in this assay, from the lowest: compound 2; then compound 4; then compound 1; then compound 3.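

Configuration alone matters at this stereocentre: in this assay there is an 8.2-fold lower number from compound 1 to compound 4 (0.91 log units; beyond the scatter), with no atom or bond changed. The earlier compounds shown here differ from one another in several places at once, so they could not show this. A mixture can read stronger than compound 1 in this way only if the form drawn in compound 1 is not the one carrying most of the activity, which points to the opposite form as the stronger one, and this reading rests on a single fact: the fact that one of compounds 1 and 4 is drawn with a defined configuration and the other without, at the place where they differ

As far as these compounds go, how the opposite form reads on its own stays open, as does the ratio of the two forms in compound 4. Also open, from the compounds shown here alone, is whether a hydroxyl group or a longer chain at this stereocentre would keep the number low.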